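This account rests on a few compounds, and the source may have more. Where it says the series, first, only, none or still open, it means among the compounds named here.

Measured in a physicochemical assay for solubility, in phosphate buffer; a higher number here means a more soluble compound, a lower number a less soluble compound:
- Compound 1 `C[C@H](CO)N1C[C@H](C)[C@@H](CN(C)Cc2ccc(Oc3ccccc3)cc2)Oc2c(NC(=O)c3ccncc3)cccc2C1=O`: 2000 nM
- Compound 2 `C[C@H]1CN([C@@H](C)CO)C(=O)c2cccc(NC(=O)c3ccncc3)c2O[C@H]1CN(C)Cc1ccc(Oc2ccccc2)cc1`: 93000 nM
- Compound 3 `C[C@@H]1CN([C@H](C)CO)C(=O)c2cccc(NC(=O)c3ccncc3)c2O[C@H]1CN(C)Cc1ccc(Oc2ccccc2)cc1`: 1000 nM

Compound 3 stands level with compound 1, a 2.0-fold lower number from compound 1 to compound 3 (0.30 log units; within the scatter), and far under compound 2, a 93-fold lower number from compound 2 to compound 3 (1.97 log units; beyond the scatter). Compound 4 `C[C@@H]1CN([C@@H](C)CO)C(=O)c2cccc(NC(=O)c3ccncc3)c2O[C@H]1CN(C)Cc1ccc(Oc2ccccc2)cc1` departs from it thus: the two compounds have the same atoms and bonds and differ only in configuration as drawn: 1 of 3 stereo elements differ; a stereocentre at a saturated chain carbon is drawn R in compound 3 and S in compound 4. Two large steps involve this chain stereocentre, a 47-fold higher number from compound 1 to compound 2 (1.67 log units; beyond the scatter) and a 93-fold lower number from compound 2 to compound 3 (1.97 log units; beyond the scatter), but each also changes a ring stereocentre. When only the two ring stereocentres change, the step, a 2.0-fold lower number from compound 1 to compound 3 (0.30 log units; within the scatter), stays within the scatter. For the measured compounds named here, no measured step isolates the chain stereocentre, so a sizeable rise in this assay is expected, though with wide uncertainty. The expected change is a 15-fold higher number from compound 3 to compound 4 (1.18 log units; beyond the scatter). For compound 4 the estimated value is 15000 nM, with an expected range of 1500 nM to 90000 nM.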

Compound 4, solubility: 1000 nM
The estimate for compound 4 lay 15-fold (1.18 log units) above the measured number, and the stated range ends above it.
By their numbers in this assay, from the lowest: compounds 3, 4 and 1 (each within the scatter of the next); then compound 2.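

In this assay, for the compounds shown here, the chain stereocentre, tested alone for the first time, shows no change at the digits printed from compound 3 to compound 4 (within the scatter), so inverting it by itself leaves the number unmoved between this pair. Going by these compounds alone, a single ring stereocentre also stands alone for the first time, with a 93-fold lower number from compound 2 to compound 4 (1.97 log units; beyond the scatter), so the large steps involving compound 2 no longer need the chain stereocentre to account for them. The mirror-image pair gives a 2.0-fold lower number from compound 1 to compound 4 (0.30 log units; within the scatter), within the scatter.

On these data alone, whether the chain stereocentre stays silent with the ring configuration of compound 2 remains open. So does whether an amine or carboxylic acid on that chain would alter the picture.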